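This account rests on a few compounds, and the source may have more. Where it says the series, first, only, none or still open, it means among the compounds named here.

Compound 1, `COC1(c2cc(F)cc(Sc3ccc4c(c3)CC/C4=N\OCC#N)c2)CCOCC1`, gives 30 nM.
Compound 2, `CO[C@]1(c2cc(F)cc(S(=O)(=O)c3ccc(/C(C)=N/OCC#N)cc3)c2)CCO[C@@H](C)C1`, gives 60 nM.
Compound 3, `CS/C(=N\O)c1ccc(Sc2cc(F)cc(C3CCOCC3)c2)cc1`, gives 190 nM.

All three numbers come from a functional assay (blood) for inhibition, with Homo sapiens as the target; a lower number here means a stronger inhibitor, a higher number a weaker inhibitor. On these numbers compound 3 stands highest of the three: compound 2 gives a lower number, and compound 1 a lower number still, and each of those two gaps to compound 3 is beyond the usual scatter of this assay. Compound 4, `C/C(=N\OCC#N)c1ccc(Sc2cc(F)cc(C3CCOCC3)c2)cc1`, has not yet been measured. It differs from compound 3 in one place: a group of 7 heavy atoms (4 carbon, 2 nitrogen, 1 oxygen; no ring) in place of a group of 5 heavy atoms (2 carbon, 1 nitrogen, 1 oxygen, 1 sulfur; no ring), on an aromatic carbon. Within the data shown here, no pair of measured compounds shows this same change, so there is no measured step to lean on, and only the structural change itself and the three numbers above can guide an expectation. A step of modest size, toward a lower number in this assay, is what is expected here, with a real chance that the change stays within the scatter. Compound 4 is expected to give about 80 nM, most likely between 30 nM and 220 nM. That estimate means a step from compound 3 of a 2.4-fold lower number from compound 3 to compound 4 (0.38 log units; beyond the scatter).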

Compound 4, half-maximal inhibitory concentration: 20 nM
Beside the measured number, compound 4's estimate is 4.0-fold (0.60 log units) above it; the measured number lies below the stated range.
By their numbers in this assay, from the lowest: compounds 4, 1 and 2 (each within the scatter of the next, the first and the last beyond it); then compound 3.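

In this assay, the group on this aromatic carbon, para to a large group, proves to matter a great deal: exchanging it, with the rest of the molecule unchanged, gives a 9.5-fold lower number from compound 3 to compound 4 (0.98 log units; beyond the scatter). Among these compounds, this pair is the first here that differs in one place, so it gives the first direct reading of this position, which the earlier compounds could not give. The entering group has 7 heavy atoms, a triple bond and 0 hydrogen-bond donors, whereas the leaving group has 5 heavy atoms, a sulfur and 1 hydrogen-bond donor.

No measurement available here explains the size of this step. On these data alone, since these features change together, it remains open which of them carries the step, and how an amine or a carboxylic acid on this same aromatic carbon would read in this assay.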